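Swapping methoxy for fluoro on a shared thiosemicarbazone core

The compounds below may be only part of what the source reports. "The series", "measured", "known", "first", "only" and "open" are said of these compounds alone.

Three compounds share one core. Compound 1 `CC1=CC[C@H](C(C)(C)N=C=S)CC1` has "not determined" (no result reported) in a functional assay on UACC-62 cells (Homo sapiens) for inhibition, read by sulforhodamine B assay, with a stated time of 48 h (on this read-out higher numbers stand for weaker inhibition of growth and lower numbers for stronger inhibition of growth), and compound 2 `CC1=CC[C@H](C(C)(C)NC(=S)NN)CC1` likewise has "not determined" (no result reported) in this assay. For the measured compounds named here, compound 3 `COc1ccc(/C=N/NC(=S)NC(C)(C)[C@H]2CC=C(C)CC2)cc1` is therefore the only one with a number: in this assay compound 3 gives 70400 nM, a weak result, and no comparison with another measured compound can be drawn from it. Compound 4 `CC1=CC[C@H](C(C)(C)NC(=S)N/N=C/c2ccc(F)cc2)CC1` differs from compound 3 in one place: fluoro in place of methoxy on an aromatic carbon. Going by the values given here, no measured pair shows what such a swap does here, so the step of a 1.0-fold lower number from compound 3 to compound 4 (0.00 log units; within the scatter) is expected to stay within the usual scatter, in no particular direction. Compound 4 is thus estimated at 70000 nM in this assay, with an expected range from 25000 nM to 200000 nM.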

Compound 4, concentration for total growth inhibition: > 100000 nM
Compound 4 gave a limit, no number; the forecaster's own chance of this, stated with the estimate: 25%; middle value at least 1.4-fold (0.15 log units) from the limit.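

Putting fluoro in place of methoxy gives an at least 1.4-fold higher number from compound 3 to compound 4 (0.15 log units; that floor lies within the scatter), so this first measured swap at this position brings no stronger inhibition of growth in this assay. Compound 4 gives only a limit of the assay and not a number: the limit of > 100000 nM in this assay, at which 1 of the 4 values shown sits. As far as these compounds go, the real size of the step therefore stays unknown, and it may or may not go beyond the scatter.

Open, from the compounds shown here alone, is whether any other group on this aromatic carbon, such as an amine or a carboxylic acid, would give stronger inhibition of growth than methoxy or fluoro.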